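Thioxo to oxo core swap with hydroxy to nitro

The source may report more compounds than this note shows. Statements on the series, on what has been measured and on what is new or still open speak of the compounds shown alone.

Measured compounds:
compound 1 `COc1ccc(-c2ssc(=S)c2-c2cc(OC)c(OC)c(OC)c2)cc1O`, 231 nM
compound 2 `COc1ccc(-c2ssc(=S)c2-c2cc(OC)c(OC)c(OC)c2)cc1[N+](=O)[O-]`, 9140 nM
compound 3 `COc1ccc(-c2ssc(=O)c2-c2cc(OC)c(OC)c(OC)c2)cc1O`, 1910 nM

In a functional assay on HT-1080 cells (Homo sapiens) for antiproliferative activity, read by MTT assay, with a stated time of 72 h (a lower number here means a stronger inhibitor, a higher number a weaker inhibitor), compound 1 gives 231 nM. The change nitro in place of hydroxy on an aromatic carbon carries a 40-fold higher number from compound 1 to compound 2 (1.60 log units; beyond the scatter). Compound 3 carries the other core; the difference between the two cores is not broken down here. Compound 3 gives 1910 nM, a higher number than compound 1 and lower than compound 2.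

Compound 4 `COc1ccc(-c2ssc(=O)c2-c2cc(OC)c(OC)c(OC)c2)cc1[N+](=O)[O-]` is not yet measured. It differs from compound 3 by nitro in place of hydroxy on an aromatic carbon, the same change as from compound 1 to compound 2, at the same place. For the measured compounds named here, on the core of compound 3 the step is expected to be of similar size, a 31-fold higher number from compound 3 to compound 4 (1.50 log units; beyond the scatter), because the only comparable step is a 40-fold higher number from compound 1 to compound 2 (1.60 log units; beyond the scatter). Compound 4 is therefore estimated at 60000 nM, between 15000 nM and 200000 nM.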

Compound 4, half-maximal inhibitory concentration: 4220 nM
Compound 4: the middle estimate sits 14-fold (1.15 log units) above what was measured, outside the stated range (below it).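

In this assay, nitro in place of hydroxy on an aromatic carbon gives a 2.2-fold higher number from compound 3 to compound 4 (0.34 log units; beyond the scatter), so the direction of the change holds on the second core, but its size does not carry over: the same change on two cores in this assay, a 40-fold higher number (1.60 log units; beyond the scatter) from compound 1 to compound 2 and a 2.2-fold higher number (0.34 log units; beyond the scatter) from compound 3 to compound 4, 18-fold (1.25 log units) apart, beyond the scatter of two such steps. In this series, the step measured on one core therefore cannot be applied as a fixed increment to the other. These two pairs do not show why the size differs, and they give no rule for any third core.

The compounds shown leave open how other groups in place of the hydroxy, such as an amine or a carboxylic acid, would behave on the two cores. On these data alone, whether those steps would also depend on the core remains open too.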